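The source may report more compounds than this note shows. Statements on the series, on what has been measured and on what is new or still open speak of the compounds shown alone.

Among the measured compounds shown here, in a functional assay on the whole organism (stomach) for inhibition, with Rattus norvegicus as the target (a higher number here means that more compound is needed for the effect, a lower number that less compound is needed), compound 1 (`COc1ccc(C[S+]([O-])c2ncccc2C(=O)Nc2ccncc2)c(OC)c1`) gives 4.2 mg/kg and compound 2 (`COc1ccc(C[S+]([O-])c2ncccc2C(=O)Nc2ccncc2)c(OCCF)c1`) gives 8.1 mg/kg, so compound 1 stands level with the only other measured compound. Compound 3 (`COc1cc(OC)c(C[S+]([O-])c2ncccc2C(=O)Nc2ccncc2)c(OC)c1`) differs from compound 1 by methoxy in place of hydrogen on an aromatic carbon. For the measured compounds named here, the one measured step, a 1.9-fold higher number from compound 1 to compound 2 (0.29 log units; within the scatter), is a different change and offers only loose guidance. It stays within the scatter, so no step beyond the scatter is expected here. The expected step is a 1.2-fold higher number from compound 1 to compound 3 (0.08 log units; within the scatter). Compound 3 is estimated at 5 mg/kg, with an expected range of 2 mg/kg to 12 mg/kg.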

Compound 3, dose for half-maximal effect: 6.8 mg/kg
Beside the measured number, compound 3's estimate is 1.4-fold (0.13 log units) below it, within the range that was stated.
By their numbers in this assay, from the lowest: compounds 1, 3 and 2 (each within the scatter of the next).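

In this assay, methoxy on the aromatic carbon ortho to a large group gives a 1.6-fold higher number from compound 1 to compound 3 (0.21 log units; within the scatter) and so stays within the scatter. This carbon of the ring can therefore carry a methoxy group without a step beyond the scatter, which compound 2, changed on a chain at another place, could not show. No measured evidence explains this result.

From the compounds shown here alone, whether an amine, a carboxylic acid or a longer chain on the same carbon would also stay within the scatter remains open.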